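Removing a Second Methoxy From Compound 1

The source may hold more compounds than are shown below. What is called first, only, known or untested is meant among the compounds shown, and "the series" means these compounds.

Compound 1 `COc1ccc(C(O)C#CCOCc2ccc(SC)cc2)c(OC)c1OC` has the lower of the two numbers given in an assay on isolated protein for inhibition of Polyunsaturated fatty acid 5-lipoxygenase (Homo sapiens) (on this read-out lower numbers stand for stronger inhibition and higher numbers for weaker inhibition), compound 1 giving 72000 nM, though its step to compound 3 lies within the scatter. Compound 3 `COc1ccc(C(O)C#CCOCc2ccc(SC)cc2)cc1OC` gives 80000 nM in this assay, and the step of a 1.1-fold higher number from compound 1 to compound 3 (0.05 log units; within the scatter) is flat. Compound 2 `OC(C#CCOCc1ccccc1)c1ccccc1` gives only a limit in this assay, > 100000 nM, not a number. Within the data shown here, the move to compound 4 `COc1cccc(C(O)C#CCOCc2ccc(SC)cc2)c1OC` is hydrogen in place of methoxy on an aromatic carbon, a change of the same kind as the one from compound 1 to compound 3 but at a different methoxy. Among the measured compounds shown here, the sole comparable step, a 1.1-fold higher number from compound 1 to compound 3 (0.05 log units; within the scatter), showed no change beyond the scatter, so none is expected here either. On that basis compound 4 is expected at 80000 nM in this assay, estimated between 40000 nM and 160000 nM, an expected step of a 1.1-fold higher number from compound 1 to compound 4 (0.05 log units; within the scatter).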

Compound 4, half-maximal inhibitory concentration: 69000 nM
The estimate for compound 4 lay 1.2-fold (0.06 log units) above the measured number; measured number inside the range.
By their numbers in this assay, from the lowest: compounds 4, 1 and 3 (each within the scatter of the next). At a limit, above all of these: compound 2.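

In this assay, the methoxy para to a large group can give way to hydrogen with no change beyond the scatter: a 1.0-fold lower number from compound 1 to compound 4 (0.02 log units; within the scatter). Hydrogen in place of methoxy is therefore flat at a second methoxy of the core of compound 1, not only at the one behind compound 3.

From the compounds shown here alone, whether an amine or a carboxylic acid on this aromatic carbon would shift the number beyond the scatter remains open. Compound 2 gives a limit, not a number: the limit of > 100000 nM in this assay, at which 1 of the 4 values shown sits.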